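A few compounds are considered here, and "the series" means these few. Any claim that something is new, unique, unknown or untested is made for them only; others in the source may bear on it.

Working notes on the series. In a functional assay on HepG2 cells (Homo sapiens) for inhibition, read by scintillation counting, with a stated time of 2 h (a lower number here means a stronger inhibitor, a higher number a weaker inhibitor), compound 1 (`CCNC(=O)Nc1sc2ccccc2c1C(=O)N1CCN(C2CCN(C(=O)C(C)C)CC2)CC1`) stands at "not determined" (no result reported), so it gives no number from which to start. Within the data shown here, the only number so far belongs to compound 2 (`CCNC(=O)Nc1sc2ccccc2c1C(=O)N1CCN(C2CCN(C(=O)C(C)(C)C)CC2)CC1`), which reads 450 nM. Compound 3 (`CCNC(=O)Nc1sc2cc(C)ccc2c1C(=O)N1CCN(C2CCN(C(=O)C(C)C)CC2)CC1`) is still to be measured in this assay. Compound 3 differs from compound 1 by methyl in place of hydrogen on an aromatic carbon. Among the measured compounds shown here, no measured step shows what such a change does. The expected step in this assay is therefore none beyond the scatter, in neither direction, and the wide range reflects how little is known. The estimate is anchored on compound 2 at 450 nM. For compound 3, the expected half-maximal inhibitory concentration is 400 nM, with an estimated range of 120 nM to 1300 nM.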

Compound 3, half-maximal inhibitory concentration: 628 nM
Compound 3: the middle estimate sits 1.6-fold (0.20 log units) below what was measured; the range from low to high includes it.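

In this assay, among these compounds, compound 1 carries no number, so no step from it to compound 3 can be read. The compounds shown leave open what methyl in place of hydrogen on the aromatic carbon does to inhibition. No evidence bears on this result.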